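Isobutyl in Place of Isopropyl: Expecting Compound 4

The compounds below may be only part of what the source reports. "The series", "measured", "known", "first", "only" and "open" are said of these compounds alone.

Four compounds share a common core and differ at an amine nitrogen in a ring. Compound 1 `CC(C)[N+]1(C)CCc2c(sc(NC(=O)Nc3ccc(Cl)cc3)c2C(N)=O)C1` and compound 2 `CC(C)C[N+]1(C)CCc2c(sc(NC(=O)Nc3ccc(Cl)cc3)c2C(N)=O)C1` carry a positively charged nitrogen there, whereas compound 3 `CC(C)N1CCc2c(sc(NC(=O)Nc3ccc(Cl)cc3)c2C(N)=O)C1` and compound 4 `CC(C)CN1CCc2c(sc(NC(=O)Nc3ccc(Cl)cc3)c2C(N)=O)C1` carry an uncharged one. How the core of compound 3 differs from the core of compound 1 is not broken down here.

In a functional assay (strain AB) with Danio rerio as the target, read by microscopy, with a stated time of 1 h (a lower number here means that less compound is needed, a higher number that more compound is needed for the effect), compound 1 gives 960 nM, and compound 2 gives 380 nM. The change between them is isobutyl in place of isopropyl on an amine nitrogen in a ring This change brought a 2.5-fold lower number from compound 1 to compound 2 (0.40 log units; beyond the scatter). Compound 3 gives 1490 nM in this assay; its number and that of compound 1 lie within the usual scatter of each other, while compound 2 sits beyond that scatter from both.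

The same change now leads from compound 3 to compound 4: isobutyl in place of isopropyl on an amine nitrogen in a ring Because the same change gave a 2.5-fold lower number from compound 1 to compound 2 (0.40 log units; beyond the scatter), a step of similar size is expected here, a 2.5-fold lower number from compound 3 to compound 4 (0.40 log units; beyond the scatter), though this rests on a single earlier pair. Compound 4 is therefore estimated at 600 nM, most likely between 300 nM and 1200 nM.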

Compound 4, half-maximal effective concentration: 4510 nM
Beside the measured number, compound 4's estimate is 7.5-fold (0.88 log units) below it; the measured number lies above the stated range.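

On the uncharged core, in this assay, isobutyl in place of isopropyl on the amine nitrogen in a ring brought a 3.0-fold higher number from compound 3 to compound 4 (0.48 log units; beyond the scatter), which runs in the opposite direction to the step on the charged core. Set side by side, the two results clearly disagree: the same change on two cores in this assay, a 2.5-fold lower number (0.40 log units; beyond the scatter) from compound 1 to compound 2 and a 3.0-fold higher number (0.48 log units; beyond the scatter) from compound 3 to compound 4, 7.6-fold (0.88 log units) apart, beyond the scatter of two such steps. This shows that, in this series, the effect of the change seen on one core cannot simply be carried over to the other, but it does not show what makes the two cores behave differently, and each direction rests on a single pair of compounds.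

The compounds shown leave open whether a longer chain, such as n-butyl, or a cyclopropylmethyl group on this nitrogen would follow the same opposite directions on the two cores. They also leave open whether a change elsewhere on the molecule, such as replacing the chlorine on the phenyl ring with a methoxy group, would carry over between the cores any better.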